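The source may hold more compounds than are shown below. What is called first, only, known or untested is meant among the compounds shown, and "the series" means these compounds.

Going by the values given here, compound 3 `CC(C)(C)N(NC(=O)c1cccc(Br)c1)C(=O)c1ccccc1Cl` gives 191 nM in an assay on cells for agonist activity at ecdysone receptor (Bombyx mori), read by a luciferase reporter, with a stated time of 24 h (a higher number here means that more compound is needed for the effect, a lower number that less compound is needed), the highest of the three numbers measured so far; compound 1 `CC(C)(C)N(NC(=O)c1ccccc1)C(=O)c1ccccc1Cl` gives 75.9 nM and compound 2 `CC(C)(C)N(NC(=O)c1cccc(F)c1)C(=O)c1ccccc1Cl` gives 69.2 nM. Compound 4 `COc1cccc(C(=O)NN(C(=O)c2ccccc2Cl)C(C)(C)C)c1` differs from compound 3 by methoxy in place of bromo on an aromatic carbon. Among the compounds with values here, no measured step involves a methoxy, so only the removal of the bromo has precedent, and that in reverse: a 2.5-fold higher number from compound 1 to compound 3 (0.40 log units; beyond the scatter) and a 2.8-fold higher number from compound 2 to compound 3 (0.44 log units; beyond the scatter), while a 1.1-fold lower number from compound 1 to compound 2 (0.04 log units; within the scatter). Because a 2.5-fold higher number from compound 1 to compound 3 (0.40 log units; beyond the scatter) and a 2.8-fold higher number from compound 2 to compound 3 (0.44 log units; beyond the scatter) tie the bromo to the higher number, the number for compound 4 is expected to fall back toward the other two. For compound 4 the expected step is a 1.9-fold lower number from compound 3 to compound 4 (0.28 log units; within the scatter) in this assay. The estimate for compound 4 is 100 nM, within a range from 40 nM to 250 nM.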

Compound 4, half-maximal effective concentration: 52.5 nM
Beside the measured number, compound 4's estimate is 1.9-fold (0.28 log units) above it; the range from low to high includes it.
By their numbers in this assay, from the lowest: compounds 4, 2 and 1 (each within the scatter of the next); then compound 3.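

At this position, methoxy reverses the rise seen with bromo (a 3.6-fold lower number from compound 3 to compound 4 (0.56 log units; beyond the scatter)), while its steps against hydrogen (a 1.4-fold lower number from compound 1 to compound 4 (0.16 log units; within the scatter)) and fluoro (a 1.3-fold lower number from compound 2 to compound 4 (0.12 log units; within the scatter)) show no real change. A group with more heavy atoms than bromo is therefore tolerated here, so heavy-atom count alone does not set bromo apart. Nothing available explains why bromo alone stands out.

Still open, as far as these compounds go, is whether an ethoxy, an amine or a carboxylic acid at this place would match compound 4 or compound 3. From the compounds shown here alone, whether chloro would behave like bromo is also open.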